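The source may report more compounds than this note shows. Statements on the series, on what has been measured and on what is new or still open speak of the compounds shown alone.

Values measured in an ADME assay on NIH3T3 cells (Mus musculus) for cytotoxicity, read by neutral red uptake, with a stated time of 48 h; a lower number here means that less compound is tolerated, a higher number that more compound is tolerated:

- Compound 1 `CCCCCCCC/C=C\c1c(C)nc(C)c(/C=C\CCCCCCCC)c1C`: "not determined" (no result reported)
- Compound 2 `CCCCCCCCCCc1c(C)cc(C)[n+]2c1CCC2`: 3.2 uM
- Compound 3 `CCCCCCCC/C=C/c1c(C)c(/C=C/CCCCCCCC)c2[n+](c1C)CCC2`: 2.5 uM

Compound 3, at 2.5 uM, lies within the scatter of compound 2, at 3.2 uM, while compound 1 offers no number for comparison. The next compound to be measured is compound 4 `CCCCCCCC/C=C\c1c(C)c(/C=C/CCCCCCCC)c2[n+](c1C)CCC2`, and the change from compound 3 is small: the two compounds have the same atoms and bonds and differ only in configuration as drawn: 1 of 2 stereo elements differ; a double bond is drawn E in compound 3 and Z in compound 4. Among the measured compounds shown here, no step between measured compounds shows what such a change does in this assay, so no shift beyond the scatter is expected, and no direction is favoured. The expected step is a 1.0-fold higher number from compound 3 to compound 4 (0.02 log units; within the scatter). For compound 4 the estimated value is 2.6 uM, with an expected range of 1.2 uM to 5.5 uM.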

Compound 4, half-maximal toxic concentration: 3.7 uM
The estimate for compound 4 lay 1.4-fold (0.15 log units) below the measured number, and the stated range covers the measured number.
By their numbers in this assay, from the lowest: compounds 3, 2 and 4 (each within the scatter of the next).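

In this assay, among the compounds shown here, this is the first measured step that tests the geometry of a double bond, and redrawing one of them from E to Z gives a result within the scatter (a 1.5-fold higher number from compound 3 to compound 4 (0.17 log units; within the scatter)). The assay therefore does not separate these two geometries at this position. The comparison is a clean one, with no other structural difference to weigh: the fact that compounds 3 and 4 differ only in the configuration as drawn.

Still open, going by these compounds, is whether changing the second double bond as well would also stay within the scatter. Also open, on these data alone, is whether an amine or a carboxylic acid in place of these chains would shift the number in this assay beyond it.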